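The source may report more compounds than this note shows. Statements on the series, on what has been measured and on what is new or still open speak of the compounds shown alone.

Measured compounds:
- compound 1 `CCC(=O)[C@H]1O[C@@H](n2cnc3c(N)nc(C#Cc4ccccc4)nc32)[C@H](O)[C@@H]1O`, in an assay on CHO cells for displacement of a labelled ligand from adenosine receptor A1 (Homo sapiens) (a higher number here means a weaker inhibitor, a lower number a stronger inhibitor), compound 1 gives 3920 nM
- compound 2 `CCNC(=O)[C@H]1O[C@@H](n2cnc3c(NOC)nc(I)nc32)[C@H](O)[C@@H]1O`, in this assay compound 2 gives 53 nM

Within the data shown here, compound 2 has the lower of the two numbers; compound 1 sits far above it, a gap well beyond the scatter, though the two differ in more than one place, so no single step is defined. Compound 3 `CCNC(=O)[C@H]1O[C@@H](n2cnc3c(NOC)nc(C#Cc4ccc(F)cc4)nc32)[C@H](O)[C@@H]1O` carries 2-(4-fluorophenyl)ethynyl in place of iodo on an aromatic carbon. Compound 1 also bears an arylethynyl group at that carbon and shows the weak end of the series. From compound 2 the step of a 9.4-fold higher number from compound 2 to compound 3 (0.97 log units; beyond the scatter) is expected to weaken binding clearly beyond the scatter. Compound 3 is estimated at 500 nM, range 100 nM to 3000 nM.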

Compound 3, inhibition constant: 1880 nM
Beside the measured number, compound 3's estimate is 3.8-fold (0.58 log units) below it, within the range that was stated.
By their numbers in this assay, from the lowest: compound 2; then compound 3; then compound 1.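

In this assay, among these compounds, a 35-fold higher number from compound 2 to compound 3 (1.55 log units; beyond the scatter) gives the first single-place reading at the aromatic carbon between two ring nitrogen atoms, where 2-(4-fluorophenyl)ethynyl replaces iodo. With the rest of the molecule held constant, binding at this position clearly depends on the group it carries, and iodo is the better of the two. Nothing measured here accounts for the size of this step.

Going by these compounds, it remains open whether an amine or a short alkyl chain at this carbon would stay closer to compound 2. Also open, on these data alone, is whether the step keeps its size with a plain amino group in place of methoxyamino.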